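Thioether-linked aminophenyl benzamide series: growth inhibition notes

The source may report more compounds than this note shows. Statements on the series, on what has been measured and on what is new or still open speak of the compounds shown alone.

Measured so far:
compound 1 `COc1ccc(SCc2ccc(/C=C/C(=O)Nc3ccccc3N)cc2)cc1OC` — 65.5%
compound 2 `Nc1ccccc1NC(=O)c1ccc(CSc2ccc(C(F)(F)F)cn2)cc1` — 37.1%

In a functional assay on A549 cells (Homo sapiens) for inhibition, read by CCK-8 assay, with a stated time of 72 h, tested at 2 uM (on this read-out lower numbers stand for less inhibition of growth and higher numbers for more inhibition of growth at the one concentration tested), compound 1 gives 65.5%, the highest of the two numbers in hand. The nearest is compound 2, which gives 37.1%, a gap beyond the scatter. The two differ in several places at once, so no single-point step can be read from the pair.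

Compound 3 `CC(C)(C)c1ccc(SCc2ccc(/C=C/C(=O)Nc3ccccc3N)cc2)cc1` awaits measurement in this assay. It differs from compound 1 as follows: 4-(tert-butyl)phenyl in place of 3,4-dimethoxyphenyl on a sulfur. Within the data shown here, no measured pair shows a change of this kind, so the direction of the step cannot be taken from the numbers here. The step from compound 1 to compound 3 is expected to be a number 5.5 percentage points lower from compound 1 to compound 3 (within the scatter), a small shift downward that stays within the scatter. The estimate for compound 3 in this assay is 60%, within a range from 40% to 78%.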

Compound 3, percent growth inhibition at one concentration: 71.5%
Compound 3: middle estimate off by 11.5 percentage points, on the low side; measured number inside the range.
By their numbers in this assay, from the lowest: compound 2; then compounds 1 and 3 (each within the scatter of the next).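

In this assay, among these compounds, the change on the sulfur gives the first single-place comparison, with 4-(tert-butyl)phenyl in place of 3,4-dimethoxyphenyl: a number 6 percentage points higher from compound 1 to compound 3 (within the scatter), so the two compounds are not separated. The entering group has the same count of heavy atoms as the leaving group but carbon only and no hydrogen-bond acceptors, so growth inhibition at the one concentration tested does not depend on the two oxygens of the 3,4-dimethoxyphenyl group in this pair. No measurement at hand explains this outcome.

Still open, as far as these compounds go, is whether an amine or a carboxylic acid on this phenyl group would keep growth inhibition at this level. Also open, from the compounds shown here alone, is how a phenyl group with a single methoxy group would compare with compound 1 and compound 3.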